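The compounds below may be only part of what the source reports. "The series", "measured", "known", "first", "only" and "open" are said of these compounds alone.

In a physicochemical assay for solubility (on this read-out lower numbers stand for lower solubility and higher numbers for higher solubility), compound 1 `CC1=C(C(=O)O)C(c2cccc(Cl)c2)C(C(=O)OCCC(c2ccccc2)c2ccccc2)=C(C(F)(F)F)N1` gives 3500 ug/mL. Compound 2 `COC(OC)C1=C(C(=O)OC/C=C/c2ccccc2)C(c2cccc(Cl)c2)C(C(=O)O)=C(C)N1` gives > 15000 ug/mL, and this is a limit of the assay, not a number. Compound 2 therefore has no exact position on the scale, only this limit.

Compound 3 `COc1ccccc1/C=C/COC(=O)C1=C(C(OC)OC)NC(C)=C(C(=O)O)C1c1cccc(Cl)c1` keeps the structure of compound 2 except for one small edit, which turns phenyl into 2-methoxyphenyl: methoxy in place of hydrogen on an aromatic carbon. In words, this is methoxy in place of hydrogen on an aromatic carbon, ortho to a large group.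

Going by the values given here, no measured pair here shows what this edit does, so the forecast is loose. A modest fall in this assay is expected, possibly none beyond the usual scatter, and compound 3 could also reach the same limit. The estimated change is an at least 1.2-fold lower number from compound 2 to compound 3 (0.09 log units; that floor lies within the scatter). For compound 3, the expected solubility is 12000 ug/mL, with an estimated range from 4000 ug/mL to 25000 ug/mL.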

Compound 3, solubility: 10200 ug/mL
Estimate against measurement, compound 3: 1.2-fold (0.07 log units) above, and the stated range covers the measured number.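

In this assay, methoxy in place of hydrogen on an aromatic carbon, ortho to a large group, gives an at least 1.4-fold lower number from compound 2 to compound 3 (0.16 log units; that floor lies within the scatter). Compound 2 gives > 15000 ug/mL, which is a limit of the assay and not a number. Compound 3 therefore provides the first exact value for this side chain, yet the step has only a floor and its true size cannot be read, because one end of it is a limit: the limit of > 15000 ug/mL in this assay, at which 1 of the 3 values shown sits.

The compounds shown leave open whether a different group on this same aromatic carbon, such as fluorine, methyl, hydroxyl or the longer ethoxy, would give a similar value. They also leave open what methoxy does on another carbon of the ring, although any such edit made from compound 3 could be read against an exact number.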